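Aryl substituent at the anilino ring: cyano for trifluoromethoxy

The compounds below may be only part of what the source reports. "The series", "measured", "known", "first", "only" and "open" are said of these compounds alone.

Compound 3 `CN(C)CC[C@H](CSc1ccccc1)Nc1ccc(S(=O)(=O)NC(=O)c2ccc(N3CCN(Cc4ccccc4-c4ccc(Cl)cc4)CC3)cc2)cc1OC(F)(F)F` stands at the limit of an assay on isolated protein for displacement of a labelled ligand from Bcl2-associated agonist of cell death (Homo sapiens), read by fluorescence polarization; a higher number here means a weaker inhibitor, a lower number a stronger inhibitor; in this assay compound 3 gives < 1 nM, which is a limit and not a number. Compound 2 `CN(C)CC[C@H](CSc1ccccc1)Nc1ccc(S(=O)(=O)NC(=O)c2ccc(N3CCN(Cc4ccccc4-c4ccc(Cl)cc4)CC3)cc2)cc1S(=O)(=O)C(F)(F)F` sits at the same limit, giving < 1 nM. Compound 1 `CN(C)CC[C@H](CSc1ccccc1)Nc1ccc(S(=O)(=O)NC(=O)c2ccc(N3CCN(Cc4ccccc4-c4ccc(Cl)cc4)CC3)cc2)cc1` gives 14 nM. The steps of an at least 14-fold lower number from compound 1 to compound 2 (1.14 log units; beyond the scatter) and an at least 14-fold lower number from compound 1 to compound 3 (1.14 log units; beyond the scatter) show that either group on this aromatic carbon reaches the limit; the step that the two limits leave unreadable from compound 2 to compound 3 remains unreadable due to the limit of < 1 nM in this assay, at which 2 of the 3 values shown sit. Compound 4 `CN(C)CC[C@H](CSc1ccccc1)Nc1ccc(S(=O)(=O)NC(=O)c2ccc(N3CCN(Cc4ccccc4-c4ccc(Cl)cc4)CC3)cc2)cc1C#N` carries cyano in place of trifluoromethoxy on an aromatic carbon. Among the compounds with values here, no measured step tests cyano at this place; both measured steps bear only on replacing hydrogen. A number near the limit is expected for compound 4, the step of an at least 1.5-fold higher number from compound 3 to compound 4 (0.17 log units; that floor lies within the scatter) estimated as small, giving an estimate for compound 4 of 1.5 nM between 0.3 nM and 8 nM.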

Compound 4, inhibition constant: < 1 nM
Compound 4 was reported as a limit; the forecaster's own chance of this, stated with the estimate: 40%; at least 1.5-fold (0.17 log units) between middle value and limit.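

In this assay compound 4 gives < 1 nM, a limit and not a number. The step of an at least 14-fold lower number from compound 1 to compound 4 (1.14 log units; beyond the scatter) makes cyano the third replacement for hydrogen on this aromatic carbon to reach the limit, after (trifluoromethyl)sulfonyl and trifluoromethoxy, so among the compounds shown neither fluorine nor sulfur in the group is required. The steps among compound 2, compound 3 and compound 4 cannot be read: the limit of < 1 nM in this assay, at which 3 of the 4 values shown sit.

As far as these compounds go, how these three compare remains open. Also open, from the compounds shown here alone, is whether a methyl group, an amine or a carboxylic acid on this carbon would reach the same limit.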